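Nitro in Place of Hydroxy on a Weak Inhibitor

The source may hold more compounds than are shown below. What is called first, only, known or untested is meant among the compounds shown, and "the series" means these compounds.

Of the compounds shown here, three have been measured in an assay on COS-7 cells for inhibition of patatin-like phospholipase domain-containing protein 2 (Mus musculus); a higher number here means a weaker inhibitor, a lower number a stronger inhibitor. Compound 1 `CCOC(=O)c1ccnc(-c2ccc(OCC)cc2)c1` gives 80000 nM in this assay. Compound 2 `CCOC(=O)C1CCCC(c2ccc(OCC)cc2)N1` reaches only the limit of this assay, > 200000 nM. One of the three values is thus a limit rather than a number: the limit of > 200000 nM in this assay, at which 1 of the 3 values shown sits. Compound 3 `CCOC(=O)c1cccc(-c2ccc(O)cc2)c1` gives 100000 nM in this assay, a number that lies within the usual scatter of that of compound 1, so the two cannot be set in order. Among the compounds with values here, the only other value, that of compound 2, is a limit of this assay.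

Compound 4 `CCOC(=O)c1cccc(-c2ccc([N+](=O)[O-])cc2)c1` differs from compound 3 in one place: nitro in place of hydroxy on an aromatic carbon. Within the data shown here, no pair of measured compounds shows this change, so there is no measured step to lean on, and the measured numbers point to no direction. The estimated step of no change at the digits printed from compound 3 to compound 4 (within the scatter) is expected to stay within the scatter. For compound 4 the estimate in this assay is 100000 nM, between 30000 nM and 300000 nM.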

Compound 4, half-maximal inhibitory concentration: 95000 nM
Beside the measured number, compound 4's estimate is 1.1-fold (0.02 log units) above it; the range from low to high includes it.
By their numbers in this assay, from the lowest: compounds 1, 4 and 3 (each within the scatter of the next). At a limit, above all of these: compound 2.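

In this assay, within the data shown here, nitro in place of hydroxy on an aromatic carbon, para to a large group, gives a 1.1-fold lower number from compound 3 to compound 4 (0.02 log units; within the scatter), the first measured step at this position. The hydrogen-bond donor of the hydroxy goes and a larger group with more hydrogen-bond acceptors enters, yet the two compounds cannot be set in order, so this exchange does not separate them at these high numbers. Among these compounds, nothing measured so far offers a reason for this outcome.

The compounds shown leave open whether an amine or a carboxylic acid on this same aromatic carbon would give a number beyond the scatter of compound 3. They also leave open whether nitro in place of hydroxy would read the same way on a core with a much lower number in this assay.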